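The compounds below may be only part of what the source reports. "The series", "measured", "known", "first", "only" and "open" are said of these compounds alone.

Measured so far:
Compound 1 `COc1cccc(OC)c1OCCNCCOc1ccccc1OCc1ccc(Cl)cc1` gives 14500 nM in a functional assay on PC-3 cells (Homo sapiens) for cytotoxicity, read by sulforhodamine B assay; a higher number here means a weaker inhibitor of growth, a lower number a stronger inhibitor of growth.
Compound 2 `COc1cccc(OC)c1OCCNCCOc1ccccc1OCc1cccc(C)c1` gives 32300 nM in this assay.

For the measured compounds named here, compound 2 stands highest of the two numbers in this assay; the only measured step is a 2.2-fold higher number from compound 1 to compound 2 (0.35 log units; beyond the scatter), a modest change of the group on the saturated chain carbon. Compound 3 `COc1cccc(COc2ccccc2OCCNCCOc2c(OC)cccc2OC)c1` differs from compound 2 by methoxy in place of methyl on an aromatic carbon. Going by the values given here, no measured step covers methyl against methoxy on that ring, so the one step known is only a loose guide. Compound 3 is therefore expected to show a 1.1-fold lower number from compound 2 to compound 3 (0.03 log units; within the scatter), not beyond the scatter, with an estimated value of 30000 nM in this assay, ranging from 12000 nM to 75000 nM.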

Compound 3, concentration for total growth inhibition: 15100 nM
Beside the measured number, compound 3's estimate is 2.0-fold (0.30 log units) above it; measured number inside the range.
By their numbers in this assay, from the lowest: compounds 1 and 3 (each within the scatter of the next); then compound 2.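

In this assay methoxy in place of methyl on the aromatic carbon gives a 2.1-fold lower number from compound 2 to compound 3 (0.33 log units; beyond the scatter), so the number at this position responds to a swap of this one small group, which the earlier pair could not show. 3-methoxyphenyl in place of 4-chlorophenyl gives a 1.0-fold higher number from compound 1 to compound 3 (0.02 log units; within the scatter), which leaves compound 2 as the only one set apart from the other two. Nothing at hand explains either step.

Still open, as far as these compounds go, is whether ethoxy, hydroxyl or an amine at this place would stay with compound 3 or move towards compound 2. From the compounds shown here alone, whether the methoxy gain carries over to other parts of the shared core also remains open.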